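Swapping the aryl group on the shared core

This account rests on a few compounds, and the source may have more. Where it says the series, first, only, none or still open, it means among the compounds named here.

Measured compounds:
- compound 1, `Cc1ccccc1-n1cc(CN2C(=O)C[C@@H]3CC[C@@]2(C)C3(C)C)nn1`: 150 nM
- compound 2, `COc1ccc(-n2cc(CN3C(=O)C[C@@H]4CC[C@@]3(C)C4(C)C)nn2)cc1`: 100 nM

In a functional assay on HepG2 cells (Homo sapiens) for inhibition, read by MTT assay, with a stated time of 24 h (on this read-out higher numbers stand for weaker inhibition and lower numbers for stronger inhibition), compound 2 gives the lowest of the two numbers recorded so far, and its nearest neighbour is compound 1 at 150 nM; the two lie within the scatter of each other, so neither can be called the stronger.

Compound 3, `CC1(C)[C@H]2CC[C@]1(C)N(Cc1cn(-c3cccc(Br)c3)nn1)C(=O)C2`, is not yet measured. It differs from compound 2 in one place: 3-bromophenyl in place of 4-methoxyphenyl on an aromatic nitrogen.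

Going by the values given here, only one measured step bears on this change, and it is of the same kind, an exchange of the aryl group on the ring nitrogen: a 1.5-fold lower number from compound 1 to compound 2 (0.18 log units; within the scatter). That step did not move the number beyond the scatter, so the aryl group in this position has so far shown little effect in this assay. For compound 3 the expectation is therefore a step of about a 1.3-fold higher number from compound 2 to compound 3 (0.11 log units; within the scatter), that is, no change beyond the scatter in either direction.

Compound 3 is estimated at 130 nM in this assay, with a range from 50 nM to 400 nM.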

Compound 3, half-maximal inhibitory concentration: 20 nM
For compound 3 the middle estimate is 6.5-fold (0.81 log units) above the measured one; measured number outside the range, below it.
By their numbers in this assay, from the lowest: compound 3; then compounds 2 and 1 (each within the scatter of the next).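

In this assay the aryl group on the aromatic nitrogen turns out to matter: putting 3-bromophenyl in place of 4-methoxyphenyl gives a 5.0-fold lower number from compound 2 to compound 3 (0.70 log units; beyond the scatter) and putting it in place of 2-methylphenyl gives a 7.5-fold lower number from compound 1 to compound 3 (0.88 log units; beyond the scatter) and both steps lie beyond the scatter. Going by these compounds alone, compounds 1 and 2 lie within the scatter of each other and showed no effect of this exchange, so compound 3 is the first sign that the same position can shift the number, here towards stronger inhibition. No measurement offered here explains why the 3-bromophenyl compound stands apart from the other two.

From the compounds shown here alone, whether the stronger inhibition goes with the bromine itself or with where the substituent sits on the phenyl ring stays open, as these two features change together across the three compounds. A 4-bromophenyl or a 3-methoxyphenyl group would pull the two apart, and how a plain phenyl or a 3-aminophenyl group would read at this position is also unknown.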